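The source may report more compounds than this note shows. Statements on the series, on what has been measured and on what is new or still open speak of the compounds shown alone.

Measured in a physicochemical assay for lipophilicity, using the shake flask method, measured as octanol-water partition, at pH 7.4; a lower number here means a more polar compound, a higher number a more lipophilic compound:
compound 1 `CC(=O)N[C@@H]1CCC[C@H](C(=O)Nc2cc(-c3cnn4c3CCCC4)c(Cl)cn2)C1`: 3.2
compound 2 `CC(=O)N[C@@H]1CCC[C@H](C(=O)Nc2cc(-c3cnc4n3CCCC4)c(Cl)cn2)C1`: 2.7
compound 3 `CC(=O)N[C@@H]1CCC[C@H](C(=O)Nc2cc(-c3cnc4n3CCC4)c(Cl)cn2)C1`: 2.6

Compound 2 stands second highest of the three. Compound 3 sits close, a number 0.10 log units lower from compound 2 to compound 3 (within the scatter), while compound 1 lies further off, a number 0.50 log units lower from compound 1 to compound 2 (beyond the scatter). Compound 4 `CC(=O)N[C@@H]1CCC[C@H](C(=O)Nc2cc(-c3cnn4c3NCCC4)c(Cl)cn2)C1` differs from compound 2 in one place: a group of 9 heavy atoms (6 carbon, 3 nitrogen; one five-membered aromatic ring with 2 hetero atoms, one six-membered non-aromatic ring with 2 hetero atoms) in place of a group of 9 heavy atoms (7 carbon, 2 nitrogen; one five-membered aromatic ring with 2 hetero atoms, one six-membered non-aromatic ring with 1 hetero atom), on an aromatic carbon. Going by the values given here, no measured step makes this exact change. The steps that rearranged the fused bicycle, a number 0.50 log units lower from compound 1 to compound 2 (beyond the scatter) and a number 0.60 log units lower from compound 1 to compound 3 (beyond the scatter), were modest, and the step of a number 0.10 log units lower from compound 2 to compound 3 (within the scatter) stayed within the scatter. The entering group carries one hydrogen-bond donor and one more nitrogen than the leaving group. For compound 4 a fall beyond the scatter in this assay is therefore expected, a number 0.70 log units lower from compound 2 to compound 4 (beyond the scatter). Compound 4 is estimated at 2, with a range of 1.5 to 2.5.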

Compound 4, distribution coefficient: 2.4
Compound 4: middle estimate off by 0.40 log units, on the low side, within the range that was stated.
By their numbers in this assay, from the lowest: compounds 4, 3 and 2 (each within the scatter of the next); then compound 1.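

In this assay the group with 1 hydrogen-bond donor cannot be told apart from the groups of compounds 2 and 3, with a number 0.30 log units lower from compound 2 to compound 4 (within the scatter) and a number 0.20 log units lower from compound 3 to compound 4 (within the scatter). Only the group of compound 1 stands apart from it, with a number 0.80 log units lower from compound 1 to compound 4 (beyond the scatter), so the added ring nitrogen and its donor open no gap from compounds 2 and 3 at this aromatic carbon. No measurement at hand accounts for this.

Open, on these data alone, is whether a methyl group on that ring nitrogen, or an ether oxygen in its place, would stay with compounds 2, 3 and 4 or move towards compound 1.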